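The source may report more compounds than this note shows. Statements on the series, on what has been measured and on what is new or still open speak of the compounds shown alone.

Measured compounds in a functional assay on BeWo cells (Homo sapiens) for inhibition, read by MTT assay, with a stated time of 72 h; a lower number here means a stronger inhibitor, a higher number a weaker inhibitor:
Compound 1 `CC(Nc1nnc2nncn2n1)C(=O)O`: 82200 nM
Compound 2 `CCCCCC(=O)N1CCN(c2nnc3nncn3n2)CC1`: 2960 nM
Compound 3 `CN1CCN(c2nnc3nncn3n2)CC1`: 7990 nM

Compound 3 sits second highest of the three in this assay: compound 2 gives a lower number, and compound 1 the highest. The step from compound 3 to compound 4 `CC(C)C(=O)N1CCN(c2nnc3nncn3n2)CC1` is isopropylcarbonyl in place of methyl on an amine nitrogen in a ring. For the measured compounds named here, one measured step bears on it: a 2.7-fold higher number from compound 2 to compound 3 (0.43 log units; beyond the scatter), where an acyl group on the same ring nitrogen went with the lower number. Compound 4 restores an acyl group, a shorter one than in compound 2, so a modest lowering of the number is expected for compound 4, as a 2.0-fold lower number from compound 3 to compound 4 (0.30 log units; within the scatter). In this assay compound 4 is estimated at 4000 nM, with a likely range from 2000 nM to 9000 nM.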

Compound 4, half-maximal inhibitory concentration: 1090 nM
Compound 4: the middle estimate sits 3.7-fold (0.56 log units) above what was measured; measured number below the stated range.
By their numbers in this assay, from the lowest: compound 4; then compound 2; then compound 3; then compound 1.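

In this assay, an acyl group on this ring nitrogen goes with a larger step than the earlier pair showed, with a 7.3-fold lower number from compound 3 to compound 4 (0.87 log units; beyond the scatter) on exchanging methyl for isopropylcarbonyl. For the compounds shown here, the group on the carbonyl carbon also counts, which the earlier compounds could not show: isopropyl in place of pentyl gives a 2.7-fold lower number from compound 2 to compound 4 (0.43 log units; beyond the scatter) in the same assay. Nothing at hand explains either step. The compounds shown leave open whether a plain isobutyl on the ring nitrogen, without the carbonyl, would do the same, and how a cyclopropyl or phenyl on the carbonyl carbon would read in this assay.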